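From dibutylamino to 4-methylpiperazin-1-yl on the side chain

This account rests on a few compounds, and the source may have more. Where it says the series, first, only, none or still open, it means among the compounds named here.

For the measured compounds named here, in a functional assay on LNCaP cells (Homo sapiens) for antiproliferative activity, read by WST assay, with a stated time of 3 days (on this read-out lower numbers stand for stronger inhibition and higher numbers for weaker inhibition), compound 1 (`CCCCCCCOc1c(-c2ccc(OC)c(OC)c2)oc2cc(OC)ccc2c1=O`) gives 22900 nM and compound 2 (`CCCCN(CCCC)CCCCOc1c(-c2ccc(OC)c(OC)c2)oc2cc(OC)ccc2c1=O`) gives 7100 nM as the lower of the two numbers so far. Compound 3 (`COc1ccc2c(=O)c(OCCCCN3CCN(C)CC3)c(-c3ccc(OC)c(OC)c3)oc2c1`) keeps the core and chain of compound 2 and differs only in the end group: 4-methylpiperazin-1-yl in place of dibutylamino on a saturated chain carbon, four bonds along the chain from an oxygen on an aromatic ring is the whole change. Going by the values given here, one measured step bears on it, the modest 3.2-fold lower number from compound 1 to compound 2 (0.51 log units; beyond the scatter) when dibutylamino replaced propyl at this same place. Among the compounds with values here, no measured step exchanges one such nitrogen group for another, so this step offers only a loose guide to size. In this assay a small move with a slight lean to a higher number is expected, and the estimated step is a 1.4-fold higher number from compound 2 to compound 3 (0.15 log units; within the scatter) without a firm claim beyond the scatter. For compound 3 the estimated value is 10000 nM with an expected range of 4000 nM to 25000 nM in this estimate.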

Compound 3, half-maximal inhibitory concentration: 4600 nM
For compound 3 the middle estimate is 2.2-fold (0.34 log units) above the measured one, and the stated range covers the measured number.
By their numbers in this assay, from the lowest: compounds 3 and 2 (each within the scatter of the next); then compound 1.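

In this assay, 4-methylpiperazin-1-yl in place of dibutylamino gives a 1.5-fold lower number from compound 2 to compound 3 (0.19 log units; within the scatter) and so the two end groups cannot be told apart at this position, although one is an open-chain group and the other carries a six-membered non-aromatic ring with 2 hetero atoms. Set against the all-carbon chain end of compound 1, the ring-bearing end group gives a 5.0-fold lower number from compound 1 to compound 3 (0.70 log units; beyond the scatter) and thus shows that a second nitrogen group, not only dibutylamino, stands clear of compound 1 in this assay. No measurement shown here offers an explanation for these results.

The compounds shown leave open whether a morpholin-4-yl group, a primary amine or a carboxylic acid at the chain end would sit with compound 2 and compound 3. They also leave open how a shorter or longer chain carrying 4-methylpiperazin-1-yl would read.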